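Swapping the Aryl Group on the Benzyl Amide

This account rests on a few compounds, and the source may have more. Where it says the series, first, only, none or still open, it means among the compounds named here.

Measured in a functional assay on cells (Hepatocyte, Rattus norvegicus) for inhibition, read by scintillation counting, with a stated time of 4 h; on this read-out higher numbers stand for weaker inhibition and lower numbers for stronger inhibition:
- compound 1, `Cc1ccc(CNC(=O)c2nc(-c3ccc(F)cc3)n(CC[C@@H](O)C[C@@H](O)CC(=O)O)c2C2CC2)cc1`, gives 0.1 nM
- compound 2, `COc1ccc(CNC(=O)c2nc(-c3ccc(F)cc3)n(CC[C@@H](O)C[C@@H](O)CC(=O)O)c2C2CC2)cc1F`, gives 0.2 nM
- compound 3, `CC(C)c1c(C(=O)NCc2ccccc2)nc(-c2ccc(F)cc2)n1CC[C@@H](O)C[C@@H](O)CC(=O)O`, gives 0.3 nM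

Compound 1 sits at the low end of these three values. Compound 2 lies within the scatter of it, the step being a 2.0-fold higher number from compound 1 to compound 2 (0.30 log units; within the scatter). Compound 3, which carries an isopropyl group and an unsubstituted benzyl in place of the cyclopropyl and 4-methylbenzyl of the shared core, gives a higher number, and that gap lies beyond the scatter.

Compound 4, `COc1cccc(CNC(=O)c2nc(-c3ccc(F)cc3)n(CC[C@@H](O)C[C@@H](O)CC(=O)O)c2C2CC2)c1`, has not yet been measured. It differs from compound 1 in one place: 3-methoxyphenyl in place of 4-methylphenyl on a saturated chain carbon bound to an amide-type nitrogen. Among the measured compounds shown here, the one measured step that bears on this is the change from compound 1 to compound 2, where a 3-fluoro-4-methoxyphenyl group took the place of the same 4-methylphenyl at the same position; that step stayed within the scatter. Another aryl exchange at the same position is therefore expected to produce no step beyond the scatter in this assay, with at most a slight drift toward a higher number. Compound 4 is estimated at 0.15 nM, with a range from 0.05 nM to 0.5 nM, an expected step of a 1.5-fold higher number from compound 1 to compound 4 (0.18 log units; within the scatter).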

Compound 4, half-maximal inhibitory concentration: 0.2 nM
The estimate for compound 4 lay 1.3-fold (0.12 log units) below the measured number, within the range that was stated.
By their numbers in this assay, from the lowest: compounds 1, 2, 4 and 3 (each within the scatter of the next, the first and the last beyond it).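

In this assay, 3-methoxyphenyl in place of 4-methylphenyl gives a 2.0-fold higher number from compound 1 to compound 4 (0.30 log units; within the scatter), so this second aryl exchange on the amide's benzyl carbon also stays within the scatter, even though the entering group brings an oxygen and a hydrogen-bond acceptor that 4-methylphenyl lacks. Exchanging 3-fluoro-4-methoxyphenyl for 3-methoxyphenyl gives no change at the digits printed from compound 2 to compound 4 (within the scatter), which adds a direct comparison of two oxygen-bearing aryl groups and shows no measurable difference between them. Nothing presented here explains why these exchanges leave the number within the scatter.

On these data alone, all of these groups are substituted phenyl rings, so it remains open how a pyridine ring would behave at this place. The same question stands for a phenyl ring carrying an amine or a carboxylic acid, or for a plain cyclohexyl ring.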